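The source may hold more compounds than are shown below. What is called first, only, known or untested is meant among the compounds shown, and "the series" means these compounds.

Two compounds of a shared core have been examined in an ADME assay on HEL cells (Homo sapiens) for cytotoxicity, with a stated time of 3 days; on this read-out higher numbers stand for lower toxicity in this test and lower numbers for higher toxicity in this test. Compound 1 `CCC1(Cc2ccccc2)OS(=O)(=O)C=C1OCc1ccc(Cl)c(Cl)c1` carries a 3,4-dichlorophenyl group on the ether arm. In this assay compound 1 reaches only a limit, >= 20000 nM, and no number beyond it. Compound 2 `CC(C)C1(Cc2ccccc2)OS(=O)(=O)C=C1OCc1ccccc1` is the second member, and in this assay compound 2 likewise stands at a limit, >= 80000 nM. Both results are therefore limits rather than numbers: compound 1 sits at the limit of >= 20000 nM in this assay, at which 1 of the 2 values shown sits, and compound 2 sits at the limit of >= 80000 nM in this assay, at which 1 of the 2 values shown sits, so neither compound shows measurable toxicity within the tested range, and nothing in the two values orders one above the other.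

Compound 3 `CCC1(Cc2ccccc2)OS(=O)(=O)C=C1OCc1cccc(Cl)c1` is the next compound awaiting this assay. It differs from compound 1 by hydrogen in place of chloro on an aromatic carbon, which leaves the 3-chlorophenyl group in place of the 3,4-dichlorophenyl group. Since compound 1 reached only a limit, the step is expected to be none beyond the scatter, a step that the limit leaves unreadable from compound 1 to compound 3, with a further limit the most likely outcome. Compound 3 is accordingly estimated to give 40000 nM, within a range from 15000 nM to 100000 nM.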

Compound 3, minimum cytotoxic concentration: >= 20000 nM
Compound 3 gave a limit, no number (the forecaster's own chance of this, stated with the estimate: 80%); the middle value is on the limit's open side.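

In this assay compound 1 and compound 3 both stand at limits rather than numbers, so no step can be read between the 3,4-dichlorophenyl group and the 3-chlorophenyl group. The compounds shown leave open whether hydrogen in place of chloro on that aromatic carbon changes the read-out at all.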